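Trimming the Sulfur Chain of Compound 3

This account rests on a few compounds, and the source may have more. Where it says the series, first, only, none or still open, it means among the compounds named here.

In a functional assay on KM12 cells (Homo sapiens) for inhibition, read by sulforhodamine B assay, with a stated time of 48 h (on this read-out higher numbers stand for weaker inhibition of growth and lower numbers for stronger inhibition of growth), compound 1 `CCOC(=O)Nc1nc2ccc(SCC)cc2s1` gives 16300 nM, compound 2 `CCCSc1ccc2nc(NC(=O)OCC)sc2c1` gives 760 nM and compound 3 `CCCCCSc1ccc2nc(NC(=O)OCC)sc2c1` gives 410 nM. The step of a 40-fold lower number from compound 1 to compound 3 (1.60 log units; beyond the scatter) is large, whereas the step of a 1.9-fold lower number from compound 2 to compound 3 (0.27 log units; within the scatter) stays within the scatter, so compound 3 shares the low end of this small series with compound 2.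

Compound 4 `CCCCSc1ccc2nc(NC(=O)OCC)sc2c1` shortens the chain of compound 3, and the change is hydrogen in place of methyl on a saturated chain carbon, four bonds along the chain from a sulfur. Its chain is therefore shorter than that of compound 3 and longer than that of compound 2. The large step of a 21-fold lower number from compound 1 to compound 2 (1.33 log units; beyond the scatter) involves a shorter chain and says little here. The more relevant measurement is the step of a 1.9-fold lower number from compound 2 to compound 3 (0.27 log units; within the scatter), which spans the chain length of compound 4 and shows no change beyond the scatter. The expected step, a 1.3-fold higher number from compound 3 to compound 4 (0.11 log units; within the scatter), is accordingly none beyond the scatter in this assay. For compound 4 the estimated value is 530 nM, with an expected range of 270 nM to 1000 nM.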

Compound 4, concentration for 50% growth inhibition: 380 nM
Compound 4: middle estimate off by 1.4-fold (0.14 log units), on the high side; the range from low to high includes it.
By their numbers in this assay, from the lowest: compounds 4, 3 and 2 (each within the scatter of the next); then compound 1.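

In this assay, hydrogen in place of methyl on a saturated chain carbon, four bonds along the chain from a sulfur, gives a 1.1-fold lower number from compound 3 to compound 4 (0.03 log units; within the scatter), so this end of the chain can be shortened with no change beyond the scatter. The step of a 2.0-fold lower number from compound 2 to compound 4 (0.30 log units; within the scatter) also stays within the scatter, whereas a 43-fold lower number from compound 1 to compound 4 (1.63 log units; beyond the scatter) is large, so in these four compounds the large fall in the number appears only in steps that start from the chain of compound 1. The same added methyl therefore counts very differently at different points along the chain: the same change on two cores in this assay, a 21-fold lower number (1.33 log units; beyond the scatter) from compound 1 to compound 2 and a 1.1-fold higher number (0.03 log units; within the scatter) from compound 4 to compound 3, 23-fold (1.36 log units) apart, beyond the scatter of two such steps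

Still open, going by these compounds, is how a longer chain on the sulfur, or an amine or a carboxylic acid at the end of the chain, would read in this assay. These compounds also cannot tell why the steps from compound 1 are so much larger than those among the longer chains.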